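The source may hold more compounds than are shown below. What is called first, only, known or untested is meant among the compounds shown, and "the series" means these compounds.

Three compounds have numbers in a physicochemical assay for solubility, with a stated time of 24 h, tested at 30 mg/mL (a higher number here means a more soluble compound, a lower number a less soluble compound), and compound 3 (`Cc1cc(COc2ccc(S(=O)(=O)N(C)C3(C(=O)NO)CN(C(=O)C(C)C)C3)cc2)c2ccccc2n1`) stands highest of them at 56000000 nM. Compound 2 (`Cc1cc(COc2ccc(S(=O)(=O)NC3(CC(=O)NO)CC3)cc2)c2ccccc2n1`) gives 1600000 nM, and compound 1 (`CCc1cc(COc2ccc(S(=O)(=O)NC3(CC(=O)NO)CN(C(C)=O)C3)cc2)c2ccccc2n1`) gives 400000 nM. The gaps from each of these two up to the top number lie beyond the scatter of the measurement. Among the measured compounds shown here, the three measured compounds differ from one another in more than one place, so no single-change step is available to show what one substitution does in this measurement.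

The next compound to be read is compound 4 (`Cc1cc(COc2ccc(S(=O)(=O)N(C(C)C)C3(C(=O)NO)CN(C(=O)C(C)C)C3)cc2)c2ccccc2n1`). It keeps the structure of compound 3 except for one change: isopropyl in place of methyl on a sulfonamide nitrogen.

For the measured compounds named here, with no direct precedent, the expectation rests on where the starting point sits. Compound 3, at 56000000 nM, already holds the highest number of the set, which leaves more room for a fall than for a rise. A modest step downward in this assay is therefore expected, only a little beyond the scatter. The estimated change is a 2.8-fold lower number from compound 3 to compound 4 (0.45 log units; beyond the scatter). For compound 4 the expected value is 20000000 nM, with an estimated range from 4000000 nM to 70000000 nM.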

Compound 4, solubility: 2200000 nM
Compound 4: the middle estimate sits 9.1-fold (0.96 log units) above what was measured; the whole stated range lies above it.
By their numbers in this assay, from the lowest: compound 1; then compounds 2 and 4 (each within the scatter of the next); then compound 3.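

Isopropyl in place of methyl on a sulfonamide nitrogen gives the first single-change step in this set, and in this assay the step is large (a 25-fold lower number from compound 3 to compound 4 (1.41 log units; beyond the scatter)). The earlier compounds shown here differed from one another in more than one place, so they could not tie any gap to one group, whereas this pair shows that the alkyl group at this position alone can move the number well beyond the scatter, even though neither group brings a ring, a hydrogen-bond donor or acceptor, or a net charge. No supporting measurement bears on why the step is this large.

On these data alone, with only methyl and isopropyl compared at this position, it remains open whether the number falls steadily as the group grows, or whether an ethyl group, a cyclopropyl group or a longer chain bearing a hydroxyl or an amine would behave differently. Among the compounds shown here, it is also open whether the same replacement would give a step of similar size with a different group on the acylated nitrogen of the shared core, such as acetyl in place of the one carried by compound 3 and compound 4.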